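Removing the Sulfamoyl Group: What to Expect for Compound 3

The compounds below may be only part of what the source reports. "The series", "measured", "known", "first", "only" and "open" are said of these compounds alone.

Compound 1 `N#CC1CN1C(=O)Nc1ccc(S(N)(=O)=O)cc1` was examined in a functional assay on MCF7 cells (Homo sapiens) for inhibition; a lower number here means a stronger inhibitor, a higher number a weaker inhibitor. In that assay compound 1 reached only the limit of the measurement, giving > 15000 nM, so no number stands for it; this is the limit of > 15000 nM in this assay, at which 1 of the 2 values shown sits. A second compound, compound 2 `CCCCNC(=O)N1CC1C#N`, shares part of the structure of compound 1. In this assay compound 2 likewise stops at a limit, giving > 12000 nM, which is the limit of > 12000 nM in this assay, at which 1 of the 2 values shown sits. Both measured compounds therefore show no measurable inhibition, and compound 1 stands at a limit with no number of its own that could be compared to anything.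

Compound 3 `N#CC1CN1C(=O)Nc1ccccc1` differs from compound 1 by hydrogen in place of sulfamoyl on an aromatic carbon. Going by the values given here, no measured pair shows what a change of this kind does in this assay, and the sulfamoyl group is the only piece that is taken away. The step that the limit leaves unreadable from compound 1 to compound 3 is expected to be none beyond the usual scatter, because compound 1 itself gives only > 15000 nM. Compound 3 is accordingly estimated at 20000 nM, within a range from 5000 nM to 100000 nM, and it is expected most likely to be reported again only as a limit.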

Compound 3, half-maximal inhibitory concentration: 4300 nM
For compound 3 the middle estimate is 4.7-fold (0.67 log units) above the measured one; the measured number lies below the stated range.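

With hydrogen in place of sulfamoyl on the aromatic carbon, the series gains its first number that is not a limit in this assay: the change gives an at least 3.4-fold lower number from compound 1 to compound 3 (0.54 log units; beyond the scatter), a step beyond the scatter. Going by these compounds alone, this position therefore has a readable bearing on the result, which neither of the earlier compounds could show, since compound 3 with its bare ring gives a measured inhibition and the sulfamoyl-bearing compound 1 does not. The step can be stated only as a minimum because compound 1 carries a limit and not a number: the limit of > 15000 nM in this assay, at which 1 of the 3 values shown sits.

The compounds shown leave open whether any group on this aromatic carbon would raise the number, or whether an amine, a methyl group or a carboxylic acid in the same place would stay close to compound 3. Within the data shown here, they also do not tell why the step arises, or whether the same exchange would read alike on a core other than the one shared by compound 1 and compound 3.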